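The source may report more compounds than this note shows. Statements on the series, on what has been measured and on what is new or still open speak of the compounds shown alone.

Compound 2, with the structure `CCCCNc1nc(N)nc2c1CN(Cc1cc(F)cc(F)c1)CC2`, was examined in an assay on HEK293 cells for agonist activity at Toll-like receptor 8 (Homo sapiens), read by a luciferase reporter, with a stated time of 6 h (on this read-out lower numbers stand for an effect already at smaller amounts and higher numbers for an effect only at larger amounts of compound), where compound 2 gives 0.23 uM. Its nearest neighbour is compound 1, with the structure `CCCCNc1nc(N)nc2c1CN(Cc1cccc(Cl)c1Cl)CC2`; in this assay compound 1 gives 0.18 uM. The two numbers cannot be told apart, since the step of a 1.3-fold higher number from compound 1 to compound 2 (0.11 log units; within the scatter) lies within the scatter, so compound 2 stands alongside compound 1 rather than apart from it.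

Compound 3, with the structure `CCCCNc1nc(N)nc2c1CN(Cc1ccc(OC)cc1)CC2`, has not yet been measured in this assay. It differs from compound 2 in one place: 4-methoxyphenyl in place of 3,5-difluorophenyl on a saturated chain carbon bound to an amine nitrogen in a ring. Within the data shown here, the only measured step that bears on this change is the one from compound 1 to compound 2, which also exchanged the group on the saturated chain carbon bound to an amine nitrogen in a ring, and that step stayed within the scatter. On this single comparison, no step beyond the scatter is expected from compound 2 to compound 3 in this assay, and the estimated step is a 1.3-fold higher number from compound 2 to compound 3 (0.12 log units; within the scatter). Compound 3 is therefore estimated to give 0.3 uM in this assay, within a range from 0.1 uM to 1 uM.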

Compound 3, minimum effective concentration: 0.08 uM
Compound 3: the middle estimate sits 3.8-fold (0.57 log units) above what was measured; measured number outside the range, below it.
By their numbers in this assay, from the lowest: compound 3; then compounds 1 and 2 (each within the scatter of the next).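

The saturated chain carbon bound to an amine nitrogen in a ring had so far shown no step beyond the scatter, but in this assay this position now proves able to shift the number: 4-methoxyphenyl in place of 3,5-difluorophenyl gives a 2.9-fold lower number from compound 2 to compound 3 (0.46 log units; beyond the scatter). The same group in place of 2,3-dichlorophenyl gives a 2.3-fold lower number from compound 1 to compound 3 (0.35 log units; beyond the scatter), so both modest steps run the same way and compound 3 stands apart from compound 1 and compound 2, which remain alongside each other. The exchange of 3,5-difluorophenyl for 4-methoxyphenyl keeps 8 heavy atoms and goes from 0 to 1 hydrogen-bond acceptor, but nothing available connects the step to that difference or offers any other explanation for it.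

The compounds shown leave open how far the step follows the oxygen of 4-methoxyphenyl, which a 4-hydroxyphenyl, 4-methylphenyl or 3-methoxyphenyl group at this place would help to test. They also leave open whether the step would hold with a longer chain in place of the butyl chain on the shared core, since all three compounds carry the same butyl chain.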